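The source may hold more compounds than are shown below. What is called first, only, known or untested is meant among the compounds shown, and "the series" means these compounds.

Two members of the series carry numbers. In a functional assay on SK-MEL-28 cells (Homo sapiens) for inhibition, read by sulforhodamine B assay, with a stated time of 48 h (a higher number here means a weaker inhibitor of growth, a lower number a stronger inhibitor of growth), compound 1 `O=C(Nc1cccc(-n2cc(-c3ccncc3)c(-c3ccc(Cl)c(O)c3)n2)c1)Nc1ccc(Cl)c(Cl)c1` gives 9850 nM. Compound 2 `COc1cc(-c2nn(-c3cccc(NC(=O)c4ccc(Cl)c(C(F)(F)F)c4)c3)cc2-c2ccncc2)ccc1Cl` gives only a limit, > 32500 nM, in this assay. Compound 2 thus sits at the limit of > 32500 nM in this assay, at which 1 of the 2 values shown sits, and no numeric value is available to set it against compound 1. Compound 3 `COc1cc(-c2nn(-c3cccc(NC(=O)c4cccc(C(F)(F)F)c4)c3)cc2-c2ccncc2)ccc1Cl` has not yet been measured in this assay. Compound 3 differs from compound 2 by hydrogen in place of chloro on an aromatic carbon. Going by the values given here, no step between measured compounds covers this change, so its size and direction cannot be read from the data. Since compound 2 shows only the limit > 32500 nM in this assay, compound 3 is expected to remain in the weak region. The step that the limit leaves unreadable from compound 2 to compound 3 is estimated to be small, with no direction expected beyond the scatter. For compound 3 the estimate in this assay is 35000 nM, within 10000 nM to 100000 nM, with a fair chance that only a limit is reported again.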

Compound 3, concentration for total growth inhibition: > 50000 nM
Compound 3: a limit, no number (the forecaster's own chance of this, stated with the estimate: 60%); at least 1.4-fold (0.15 log units) between middle value and limit.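

In this assay, going by these compounds alone, compound 2 and compound 3 both give only limits, so no step between compound 2 and compound 3 can be read. The compounds shown leave open whether going from 4-chloro-3-(trifluoromethyl)phenyl to 3-(trifluoromethyl)phenyl shifts growth inhibition at all, and in which direction.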